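The compounds below may be only part of what the source reports. "The series", "measured", "known", "first", "only" and "open" are said of these compounds alone.

Compound 1 `COc1cc(CNCc2ccncc2)ccc1OCc1ccccc1F`: 5100 nM
Compound 2 `COCCNCc1ccc(OCc2ccc(Cl)nc2)c(OC)c1`: 97000 nM

In a functional assay on HeLa cells (Homo sapiens) for inhibition, with a stated time of 72 h (a lower number here means that less compound is needed, a higher number that more compound is needed for the effect), compound 1 gives 5100 nM, the lower of the two numbers, and compound 2 gives 97000 nM. That gap lies beyond the usual scatter, so compound 1 needs less compound for the effect.

Compound 3 `COc1cc(CNCc2ccncc2)ccc1OCc1cccc(F)c1` has not been measured yet. It has the same atoms as compound 1, joined differently: 3-fluorophenyl in place of 2-fluorophenyl on a saturated chain carbon bound to an oxygen on an aromatic ring. In words, 3-fluorophenyl stands in place of 2-fluorophenyl on a saturated chain carbon bound to an oxygen on an aromatic ring.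

Among the measured compounds shown here, no measured pair here differs in one place only, so the data give no direct guide to this change. The expected result is no shift beyond the scatter, with an estimated 1.1-fold lower number from compound 1 to compound 3 (0.03 log units; within the scatter). For compound 3 the estimated value is 4800 nM, with an expected range from 2000 nM to 12000 nM.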

Compound 3, half-maximal effective concentration: 4800 nM
Compound 3: middle estimate and measured number agree at the digits printed, within the range that was stated.
By their numbers in this assay, from the lowest: compounds 3 and 1 (each within the scatter of the next); then compound 2.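

In this assay, placing 3-fluorophenyl in place of 2-fluorophenyl on a saturated chain carbon bound to an oxygen on an aromatic ring gives a 1.1-fold lower number from compound 1 to compound 3 (0.03 log units; within the scatter). Among the compounds shown here, this is the first comparison here in which only one place differs, and it shows that this assay cannot tell compound 1 and compound 3 apart. For these two compounds, then, the choice between the 2-fluorophenyl and 3-fluorophenyl groups makes no measurable difference, and no supporting measurement offers an explanation for that.

The compounds shown leave open whether the fluorine itself matters, since neither a plain phenyl group nor 4-fluorophenyl appears at this place. They also leave open whether a larger group, such as naphthyl, would give a clearly different number on the core of compound 1.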